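The source may hold more compounds than are shown below. What is called first, only, known or untested is meant among the compounds shown, and "the series" means these compounds.

Compound 1 `COc1ncc(-c2ccc3nccc(/C(C)=C/C(=O)N(C)CCO)c3c2)cc1NS(=O)(=O)c1ccc(F)cc1F`: 290 nM
Compound 2 `COc1ncc(-c2ccc3nccc(/C(C)=C/C(=O)N4CCCC4)c3c2)cc1NS(=O)(=O)c1ccc(F)cc1F`: 1160 nM

In a functional assay on PC-3 cells (Homo sapiens) for inhibition, read by sulforhodamine B assay, with a stated time of 72 h (a higher number here means a weaker inhibitor of growth, a lower number a stronger inhibitor of growth), compound 2, at 1160 nM, has the higher of the two numbers and is the weaker inhibitor of growth of the pair. Among the compounds with values here, the only measured step, a 4.0-fold higher number from compound 1 to compound 2 (0.60 log units; beyond the scatter), lies beyond the scatter and is modest. It puts pyrrolidin-1-yl in place of (2-hydroxyethyl)(methyl)amino on a carbonyl carbon.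

Compound 3 `COc1ncc(-c2ccc3nccc(/C(C)=C/C(=O)N4CCC(O)CC4)c3c2)cc1NS(=O)(=O)c1ccc(F)cc1F` differs from compound 2 at that same carbonyl carbon: 4-hydroxypiperidin-1-yl in place of pyrrolidin-1-yl on a carbonyl carbon. The entering 4-hydroxypiperidin-1-yl has not been measured in any compound, so the evidence is indirect. Like the group in compound 1, it carries a hydroxy group, which pyrrolidin-1-yl lacks. The step of a 4.0-fold higher number from compound 1 to compound 2 (0.60 log units; beyond the scatter) therefore suggests a move back towards a lower number, though probably not all the way, as the hydroxy group here sits on a ring rather than a chain. The expected step is a 2.6-fold lower number from compound 2 to compound 3 (0.41 log units; beyond the scatter).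

For compound 3, the estimated value is 450 nM, with an expected range from 170 nM to 1200 nM.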

Compound 3, concentration for 50% growth inhibition: 1080 nM
Compound 3: middle estimate off by 2.4-fold (0.38 log units), on the low side; low and high end bracket the measured number.
By their numbers in this assay, from the lowest: compound 1; then compounds 3 and 2 (each within the scatter of the next).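

In this assay, the step of a 1.1-fold lower number from compound 2 to compound 3 (0.03 log units; within the scatter) shows that 4-hydroxypiperidin-1-yl and pyrrolidin-1-yl on this carbonyl carbon cannot be told apart, so a hydroxy group on a six-membered ring does not by itself bring a compound back to the level of compound 1. The step of a 3.7-fold higher number from compound 1 to compound 3 (0.57 log units; beyond the scatter) stands alongside a 4.0-fold higher number from compound 1 to compound 2 (0.60 log units; beyond the scatter): with or without a hydroxy group, both ring amides give a higher number than the open-chain (2-hydroxyethyl)(methyl)amino amide of compound 1, which alone gives the lowest number of the three. Nothing available explains this difference between the open-chain amide and the two ring amides.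

The compounds shown leave open whether the advantage of compound 1 lies in the open chain or in its hydroxy group, a question that a dimethylamino group on the same carbonyl carbon would address. They also leave open how a hydroxy group placed elsewhere on a ring, as in 3-hydroxypyrrolidin-1-yl, or a ring with a second nitrogen, as in 4-methylpiperazin-1-yl, would fare in this place.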